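The compounds below may be only part of what the source reports. "The series", "measured", "known", "first", "only" and "open" are said of these compounds alone.

Measured so far in a functional assay on CHO cells with adenosine receptor A1 (Homo sapiens) as the target, read by cAMP accumulation and immunoassay, with a stated time of 6 min, tested at 0.1 uM; a lower number here means a stronger effect, a higher number a weaker effect of the compound at the concentration tested:
compound 1 `CC(C)N1CCN(Cc2csc(N)c2C(=O)c2ccc(Cl)cc2)CC1` gives 3.6%
compound 2 `Nc1scc(CN2CCN(c3ccc(OC(F)(F)F)cc3)CC2)c1C(=O)c1ccc(Cl)cc1` gives -13%

Among these two numbers compound 2 stands lowest, its nearest neighbour being compound 1, which lies higher by a gap beyond the scatter. For the measured compounds named here, the only measured step, a number 16.6 percentage points lower from compound 1 to compound 2 (beyond the scatter), put an aromatic ring onto the ring nitrogen where an isopropyl had been. Compound 3 `Nc1scc(CN2CCN(c3ccc(Cl)c(Cl)c3)CC2)c1C(=O)c1ccc(Cl)cc1` keeps an aromatic ring at that nitrogen but changes what sits on it: 3,4-dichlorophenyl in place of 4-(trifluoromethoxy)phenyl on an amine nitrogen in a ring. Going by the values given here, no measured step swaps one aromatic ring for another at this position, so the one known step speaks only indirectly; it shows that an aromatic ring here goes together with a low number. In this assay no change beyond the scatter is expected for compound 3, meaning a number 3 percentage points higher from compound 2 to compound 3 (within the scatter). Compound 3 is therefore estimated at -10%, within -30% to 10%.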

Compound 3, a percentage reported as activity, at one concentration (the size of the read-out at that concentration, not a potency): -13%
Compound 3: the middle estimate sits 3 percentage points above what was measured; measured number inside the range.
By their numbers in this assay, from the lowest: compounds 2 and 3 (each within the scatter of the next); then compound 1.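

In this assay, putting 3,4-dichlorophenyl in place of 4-(trifluoromethoxy)phenyl on the ring nitrogen gives no change at the digits printed from compound 2 to compound 3 (within the scatter) and so, at this position, the two aromatic groups cannot be told apart. The gap to the isopropyl compound also returns with the new group, as a number 16.6 percentage points lower from compound 1 to compound 3 (beyond the scatter) and the low number of compound 2 is therefore not unique to 4-(trifluoromethoxy)phenyl. Across these three compounds, both aromatic groups give lower numbers than isopropyl, and none of the three goes against this. No measured data at hand explain why the two aromatic groups match or why they differ from isopropyl. Going by these compounds, it remains open whether a plain phenyl, or a phenyl ring carrying an amine or a carboxylic acid, would stay at the same level.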